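This account rests on a few compounds, and the source may have more. Where it says the series, first, only, none or still open, it means among the compounds named here.

Measured compounds:
Compound 1 `Nc1nn(CC(=O)NC2CC2)c2nc(-c3ccccc3)cc(C(F)(F)F)c12`: "not active" (no number reported)
Compound 2 `Nc1nn(CC(=O)NC2CCCCC2)c2nc(-c3ccccc3)cc(C(F)(F)F)c12`: 3900 nM

In a functional assay on HeLa cells (Homo sapiens) for cytotoxicity, read by MTT assay, with a stated time of 24 h (on this read-out higher numbers stand for weaker inhibition and lower numbers for stronger inhibition), compound 1 gives "not active" (no number reported), so no number stands behind it. Compound 2 gives 3900 nM in this assay, the only number shown, with one further entry carrying no single value. Compound 3 `CN1CCN(C(=O)Cn2nc(N)c3c(C(F)(F)F)cc(-c4ccccc4)nc32)CC1` differs from compound 2 in one place: 4-methylpiperazin-1-yl in place of cyclohexylamino on a carbonyl carbon. Among the measured compounds shown here, no step between two measured compounds is available to guide the estimate, and compound 1 with "not active" (no number reported) shows that this series can lose measurable activity altogether. For compound 3 a modest step toward weaker inhibition is expected, a 2.1-fold higher number from compound 2 to compound 3 (0.31 log units; beyond the scatter), possibly beyond the scatter. The expected value for compound 3 is 8000 nM, in the range 2500 nM to 30000 nM.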

Compound 3, half-maximal inhibitory concentration: 17700 nM
The estimate for compound 3 lay 2.2-fold (0.34 log units) below the measured number; measured number inside the range.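

In this assay, among the compounds shown here, putting 4-methylpiperazin-1-yl in place of cyclohexylamino on the carbonyl carbon gives a 4.5-fold higher number from compound 2 to compound 3 (0.66 log units; beyond the scatter) as the first measured step at this position. The change keeps the heavy-atom count and the six-membered ring but loses the hydrogen-bond donor, and a measurable value remains. Nothing measured here explains the size of this step.

On these data alone, whether the shift follows the lost amide hydrogen or the added ring nitrogen stays open, and a piperidin-1-yl or morpholin-4-yl group on the same carbonyl carbon would help separate the two. The compounds shown also leave open how a piperazin-1-yl group without the methyl would compare.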